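Adding Chloro to a Weak Dopamine Transporter Binder

The source may report more compounds than this note shows. Statements on the series, on what has been measured and on what is new or still open speak of the compounds shown alone.

Compound 2 `c1ccc(C2=C(c3cc(-c4ccccc4)no3)C3CCC(C2)S3)cc1` was tested in an assay for displacement of a labelled ligand from sodium-dependent dopamine transporter (Homo sapiens); on this read-out higher numbers stand for weaker inhibition and lower numbers for stronger inhibition. For compound 2 the read-out is only a limit, > 5000 nM, so compound 2 stands at the limit of > 5000 nM in this assay, at which 1 of the 2 values shown sits. Compound 1 `Cc1cc(C2=C(c3ccc(Cl)cc3)CC3CCC2S3)on1` is built differently in more than one place; in this assay compound 1 gives 155 nM. Compound 3 `Clc1ccc(C2=C(c3cc(-c4ccccc4)no3)C3CCC(C2)S3)cc1` differs from compound 2 by chloro in place of hydrogen on an aromatic carbon. Within the data shown here, no single-change step between measured compounds is available, so the size of this change is unknown. A gain beyond the usual scatter is expected, as an at least 2.0-fold lower number from compound 2 to compound 3 (0.30 log units; that floor lies within the scatter). Compound 3 is therefore estimated at 2500 nM, within a range from 600 nM to 10000 nM.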

Compound 3, half-maximal inhibitory concentration: 66.5 nM
For compound 3 the middle estimate is 38-fold (1.58 log units) above the measured one; measured number outside the range, below it.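

Chloro in place of hydrogen on the six-membered aromatic ring, para to a large group, gives an at least 75-fold lower number from compound 2 to compound 3 (1.87 log units; beyond the scatter) in this assay, so a single added atom at this position makes a large difference. On these data alone, compound 2 is only a limit, so that step is a floor and its true size remains unknown: the limit of > 5000 nM in this assay, at which 1 of the 3 values shown sits. With chloro in place, phenyl in place of methyl on an aromatic carbon gives a 2.3-fold lower number from compound 1 to compound 3 (0.37 log units; beyond the scatter), a modest step.

As far as these compounds go, whether fluoro, bromo, methoxy or an amine at the same position would give a similar gain remains open.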